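The compounds below may be only part of what the source reports. "The series", "measured", "known", "first", "only" and "open" are said of these compounds alone.

Compound 1 `O=C1C[C@H](NC(=O)[C@@H]2COC[C@@H]3CCCC[C@H](NC(=O)c4nccc5ccccc45)C(=O)N32)C(O)O1`: 101 nM
Compound 2 `O=C1C[C@H](NC(=O)[C@@H]2COC[C@@H]3C/C=C\C[C@H](NC(=O)c4cccc(Cl)c4)C(=O)N32)C(O)O1`: 118 nM

Of the compounds shown here, two have been measured in a functional assay on THP-1 cells (Homo sapiens) for inhibition; a higher number here means a weaker inhibitor, a lower number a stronger inhibitor. Compound 1 gives 101 nM, the lower of the two numbers, and compound 2 gives 118 nM; the gap between them lies within the scatter, so neither can be called the stronger inhibitor. Compound 3 `O=C1C[C@H](NC(=O)[C@@H]2COC[C@@H]3CCCC[C@H](NC(=O)c4cc5ccccc5s4)C(=O)N32)C(O)O1` has not yet been measured. It differs from compound 1 in one place: 1-benzothiophen-2-yl in place of isoquinolin-1-yl on a carbonyl carbon. Among the measured compounds shown here, no step between measured compounds bears on this change, so there is nothing to guide its size. Compound 3 is therefore expected to sit close to compound 1, with a step of a 1.5-fold higher number from compound 1 to compound 3 (0.17 log units; within the scatter) that is expected to stay within the scatter or at most to be a modest weakening. The estimate for compound 3 in this assay is 150 nM, with a range from 50 nM to 450 nM.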

Compound 3, half-maximal inhibitory concentration: 178 nM
Beside the measured number, compound 3's estimate is 1.2-fold (0.07 log units) below it; low and high end bracket the measured number.
By their numbers in this assay, from the lowest: compounds 1, 2 and 3 (each within the scatter of the next).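

In this assay, putting 1-benzothiophen-2-yl in place of isoquinolin-1-yl on a carbonyl carbon gives a small step (a 1.8-fold higher number from compound 1 to compound 3 (0.25 log units; within the scatter)), the first that can be read at this position. On the core of compound 1, a group with a five-membered aromatic ring holding sulfur and a group with a six-membered aromatic ring holding nitrogen therefore cannot be told apart in this read-out, though this rests on a single pair. Nothing available explains why the two groups read so alike.

What the compounds leave open is whether this position tolerates groups of another kind, such as a piperidine, an amine or a carboxylic acid, on the same carbonyl carbon. Going by these compounds, whether a smaller group, such as methyl, would stay within the scatter also remains open.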